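This account rests on a few compounds, and the source may have more. Where it says the series, first, only, none or still open, it means among the compounds named here.

Three compounds share the same core and differ only in the ring carried at the end of a side chain. In a functional assay on MDA-MB-231 cells (Homo sapiens) for antiproliferative activity, read by MTT assay, with a stated time of 72 h (a higher number here means a weaker inhibitor, a lower number a stronger inhibitor), compound 1 `COc1cc2c(Oc3c(F)cc(NC(=O)NN4C(=O)CCSC4c4c(F)cccc4F)cc3F)ccnc2cc1OCCCN1CCCC1` gives 9650 nM, a weak result. Compound 2 `COc1cc2c(Oc3c(F)cc(NC(=O)NN4C(=O)CCSC4c4c(F)cccc4F)cc3F)ccnc2cc1OCCCN1CCc2sccc2C1` was run in this assay, but its result is recorded as "not determined" (no result reported), so there is no single number for compound 2 and nothing can be said about how it compares with compound 1. Compound 3 `COc1cc2c(Oc3c(F)cc(NC(=O)NN4C(=O)CCSC4c4c(F)cccc4F)cc3F)ccnc2cc1OCCCN1CCC(C)CC1` is the unmeasured compound; it differs from compound 2 by a group of 7 heavy atoms (6 carbon, 1 nitrogen; one six-membered non-aromatic ring with 1 hetero atom) in place of a group of 9 heavy atoms (7 carbon, 1 nitrogen, 1 sulfur; one five-membered aromatic ring with 1 hetero atom, one six-membered non-aromatic ring with 1 hetero atom), on a saturated chain carbon, three bonds along the chain from an oxygen on an aromatic ring. For the measured compounds named here, no pair of measured compounds spans this change, so the size and direction of the step from compound 2 to compound 3 in this assay cannot be read from the data. Going by the values given here, the only anchor is compound 1, which carries a different ring at the same end of the chain and gives 9650 nM in this assay. Among the compounds with values here, with no measured step to guide the expectation, a result in the same weak region as compound 1 is assumed, with wide uncertainty in both directions. Compound 3 is therefore expected to give about 8000 nM in this assay, estimated within a range from 2500 nM to 30000 nM.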

Compound 3, half-maximal inhibitory concentration: 4350 nM
Estimate against measurement, compound 3: 1.8-fold (0.26 log units) above; measured number inside the range.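

In this assay, for the compounds shown here, the ring at the end of the side chain turns out to matter: 4-methylpiperidin-1-yl in place of pyrrolidin-1-yl gives a 2.2-fold lower number from compound 1 to compound 3 (0.35 log units; beyond the scatter) and this is the first measured step at this position, modest in size but larger than the usual scatter. The change does not lift the series out of the weak region, as compound 3 still gives 4350 nM in this assay so this end of the chain shifts the number only slightly in this one comparison. Nothing available explains the shift, and no measurement links it to any property of either ring.

Compound 2 has no reported number, so the steps to and from it cannot be read, and the fused sulfur-containing ring remains uncharacterised in this assay. The step also swaps the ring and adds a methyl group at once, so a plain piperidin-1-yl ring would be needed to separate those two changes, while a morpholin-4-yl ring or a longer chain leaves further open how much this end of the molecule can move the result.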